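A few compounds are considered here, and "the series" means these few. Any claim that something is new, unique, unknown or untested is made for them only; others in the source may bear on it.

Measured compounds:
Compound 1, `Nc1sc(-c2ccc(F)cc2)c(-c2ccc(Cl)cc2)c1C(=O)N1CCCC1`: in a functional assay on A549 cells (Homo sapiens) for cytotoxicity, read by sulforhodamine B assay, with a stated time of 72 h (a lower number here means a stronger inhibitor, a higher number a weaker inhibitor), compound 1 gives 18800 nM.
Compound 2, `Nc1sc(-c2ccc(Br)cc2)c(-c2ccc(Cl)cc2)c1C(=O)N1CCCC1`: in this assay compound 2 gives 7460 nM.
Compound 3, `Nc1sc(-c2ccc([N+](=O)[O-])cc2)c(-c2ccc(Cl)cc2)c1C(=O)NC1CC1`: in this assay compound 3 gives "not determined" (no result reported), that is, no result was reported for it.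

Compound 3 therefore stands nowhere on the numbers shown; it carries a nitro group and a cyclopropylamino amide, and nothing was determined for it. Compound 4, `Nc1sc(-c2ccc([N+](=O)[O-])cc2)c(-c2ccc(Cl)cc2)c1C(=O)N1CCCC1`, differs from compound 3 in one place: pyrrolidin-1-yl in place of cyclopropylamino on a carbonyl carbon. Going by the values given here, the only measured step, a 2.5-fold lower number from compound 1 to compound 2 (0.40 log units; beyond the scatter), concerns a different change, bromo in place of fluoro on an aromatic carbon, so it does not bear directly on the amide change, and no measured pair shows what exchanging cyclopropylamino for pyrrolidin-1-yl does in this assay. What can be said is that compound 4 carries the same pyrrolidin-1-yl amide as compound 1 and compound 2, whose values lie close to each other. The number for compound 4 in this assay is therefore expected to fall near those two, at about 9000 nM, with a range from 2500 nM to 30000 nM.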

Compound 4, half-maximal inhibitory concentration: 10700 nM
Compound 4: middle estimate off by 1.2-fold (0.08 log units), on the low side, and the stated range covers the measured number.
By their numbers in this assay, from the lowest: compounds 2, 4 and 1 (each within the scatter of the next, the first and the last beyond it).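

In this assay replacing bromo with nitro on the aromatic carbon gives a 1.4-fold higher number from compound 2 to compound 4 (0.16 log units; within the scatter), and replacing fluoro with nitro gives a 1.8-fold lower number from compound 1 to compound 4 (0.24 log units; within the scatter). The earlier compounds shown here showed only that bromo and fluoro differ beyond the scatter at this place; nitro now proves indistinguishable from either of them, so this third, quite different group leaves the number in the same range. Nothing measured here explains why the number stays there.

On these data alone, compound 3 has no result, so the step from cyclopropylamino to pyrrolidin-1-yl cannot be read, and what the amide ring or the amide hydrogen contributes stays unknown. Also open, as far as these compounds go, is whether an amine or a carboxylic acid on that aromatic carbon would move the number further than nitro does.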